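Swapping an Amide for a Urea: Expected Cell Toxicity

A few compounds are considered here, and "the series" means these few. Any claim that something is new, unique, unknown or untested is made for them only; others in the source may bear on it.

Compound 1 `O=C(Nc1cccc(-n2cc(-c3ccncc3)c(-c3ccc(Cl)c(O)c3)n2)c1)Nc1ccc(Cl)c(Cl)c1` sits at the assay limit, > 32500 nM, in a functional assay on A549 cells (Homo sapiens) for inhibition, read by sulforhodamine B assay, with a stated time of 48 h; a lower number here means that less compound is tolerated, a higher number that more compound is tolerated.
Compound 2 `COc1cc(-c2nn(-c3cccc(NC(=O)c4ccc(Cl)c(C(F)(F)F)c4)c3)cc2-c2ccncc2)ccc1Cl` also sits only at the limit, > 32500 nM, in this assay.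
Compound 3 `O=C(Nc1cccc(-n2cc(-c3ccncc3)c(-c3ccc(Cl)c(O)c3)n2)c1)Nc1cc(C(F)(F)F)cc(C(F)(F)F)c1` gives a measured number, 11400 nM, in this assay.

Compound 2 therefore stands at the top end of the numbers shown: no concentration within the tested range reached the read-out, and the limit of > 32500 nM in this assay, at which 2 of the 3 values shown sit, shows that compound 1 shares this limit, while compound 3 alone gives a value inside the range. Compound 4 `COc1cc(-c2nn(-c3cccc(NC(=O)Nc4cccc(C(F)(F)F)c4)c3)cc2-c2ccncc2)ccc1Cl` differs from compound 2 in one place: (3-(trifluoromethyl)phenyl)amino in place of 4-chloro-3-(trifluoromethyl)phenyl on a carbonyl carbon. This makes compound 4 a urea like compound 1 and compound 3. The step from compound 2 to compound 4 is expected to be small or none beyond the scatter, an at least 1.1-fold lower number from compound 2 to compound 4 (0.06 log units; that floor lies within the scatter), so compound 4 is estimated at 28000 nM, between 9000 nM and 65000 nM, with a fair chance that only a limit is reported.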

Compound 4, concentration lethal to 50% of the cells: > 50000 nM
Compound 4 ended at the assay's limit; the forecaster's own chance of this, stated with the estimate: 55%; at least 1.7-fold (0.25 log units) between middle value and limit.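

Among the compounds shown here, compound 2 and compound 4 each reach only a limit in this assay, and no step between them can be read. The compounds shown leave open whether (3-(trifluoromethyl)phenyl)amino in place of 4-chloro-3-(trifluoromethyl)phenyl changes the tolerated concentration at all.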